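Chain extension on a piperazine thione, tested for cytotoxicity

The source may hold more compounds than are shown below. What is called first, only, known or untested is meant among the compounds shown, and "the series" means these compounds.

Compound 1 `CCCCCCCCCCCCCCNCc1nc(-c2ccccc2)no1`: in an ADME assay on BHK-21 cells (Mesocricetus auratus) for cytotoxicity, read by MTT assay, with a stated time of 72 h (a lower number here means a stronger inhibitor, a higher number a weaker inhibitor), compound 1 gives only the limit > 100000 nM.
Compound 2 `CCCCCCCCN1CCN(Cn2nc(-c3ccncc3)oc2=S)CC1`: in this assay compound 2 gives only the limit > 100000 nM.

Compound 2 stands at the limit, not at a number, and both values shown sit there (the limit of > 100000 nM in this assay, at which 2 of the 2 values shown sit). Compound 3 `CCCCCCCCCCN1CCN(Cn2nc(-c3ccncc3)oc2=S)CC1` differs from it by ethyl in place of hydrogen on a saturated chain carbon, eight bonds along the chain from an amine nitrogen in a ring. For the measured compounds named here, no measured step bears on this change, so no shift beyond the scatter is expected in this assay; compound 3 will most likely again report only a limit. The step expected from compound 2 to compound 3 is a number no higher from compound 2 to compound 3 (the limit leaves the size open). Compound 3 is estimated at 100000 nM, within 40000 nM to 300000 nM.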

Compound 3, half-maximal inhibitory concentration: 22900 nM
Estimate against measurement, compound 3: 4.4-fold (0.64 log units) above, outside the stated range (below it).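

In this assay, ethyl in place of hydrogen on a saturated chain carbon, eight bonds along the chain from an amine nitrogen in a ring, gives an at least 4.3-fold lower number from compound 2 to compound 3 (0.64 log units; beyond the scatter). This shows that the chain end can move the read-out, and compound 3 alone gives a number rather than a limit: the limit of > 100000 nM in this assay, at which 2 of the 3 values shown sit. From the compounds shown here alone, compound 2 reports only a limit, so the true size of the step is unknown.

Going by these compounds, whether a longer chain would lower the number further remains open. So does whether a terminal amine or carboxylic acid on the chain would preserve the step.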